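The source may report more compounds than this note shows. Statements on the series, on what has been measured and on what is new or still open speak of the compounds shown alone.

Measured compounds:
Compound 1 `COc1ccccc1C(=O)Nc1ccc(Cl)cc1F`: in an ADME assay on RAW264.7 cells (Mus musculus) for cytotoxicity, read by MTT assay, with a stated time of 24 h (on this read-out lower numbers stand for higher toxicity in this test and higher numbers for lower toxicity in this test), compound 1 gives > 40000 nM, a limit of the assay.
Compound 2 `O=C(Nc1ccc(Cl)cc1F)c1ccccc1`: in this assay compound 2 gives > 40000 nM, likewise a limit.

The step that the two limits leave unreadable from compound 1 to compound 2 is therefore not readable, and compound 2 stands only at the limit of > 40000 nM in this assay, at which 2 of the 2 values shown sit, with no number of its own.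

Compound 3 `O=C(Nc1ccc(F)cc1F)c1ccccc1` differs from compound 2 by fluoro in place of chloro on an aromatic carbon. Among the measured compounds shown here, no measured step bears on this exchange, and no direction can be drawn from the two limits. The expected step is a step that the limit leaves unreadable from compound 2 to compound 3, none beyond the scatter. Compound 3 is estimated at 60000 nM, range 20000 nM to 200000 nM, most likely again reported as a limit.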

Compound 3, half-maximal cytotoxic concentration: > 40000 nM
Compound 3 ended at the assay's limit (the forecaster's own chance of this, stated with the estimate: 85%); the middle value is on the limit's open side.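

No step can be read from compound 2 to compound 3 in this assay, since each stands only at a limit: the limit of > 40000 nM in this assay, at which 3 of the 3 values shown sit.

The compounds shown leave open whether fluoro in place of chloro, or hydrogen in place of methoxy, changes the cytotoxic concentration at all.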